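Lengthening the Amine Chain: What to Expect for Compound 4

The source may hold more compounds than are shown below. What is called first, only, known or untested is meant among the compounds shown, and "the series" means these compounds.

Compound 1, `C#CCN(C)CCCCOc1ccc2c(c1)CCCC2=O`, gives 30.9% in an ADME assay on BTI cells for inhibition of Amine oxidase [flavin-containing] A (Homo sapiens), read by fluorescence and Amplex Red, with a stated time of 15 min, tested at 100 uM; a higher number here means more inhibition at the concentration tested (going by the name of the read-out), a lower number less inhibition. Compound 2, `C#CCN(C)CCCCCCOc1ccc2c(c1)CCCC2=O`, gives 25% in this assay. Compound 3, `C#CCN(C)CCCCCCOc1ccc2c(c1)OCCC2=O`, gives 34.1% in this assay.

Compound 1 and compound 2 share a core and differ in one place: 2-(methyl(propargyl)amino)ethyl in place of methyl(propargyl)amino on a saturated chain carbon, four bonds along the chain from an oxygen on an aromatic ring. That change gave a number 5.9 percentage points lower from compound 1 to compound 2 (within the scatter), so the two numbers cannot be told apart with confidence. Compound 3 is built on a different core from compound 1, and the difference between the two cores is not broken down here. Its number in this assay and those of compound 1 and compound 2 all lie within the usual scatter of one another, so none of the three numbers can be called higher or lower than another.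

Compound 4, `C#CCN(C)CCCCCCCCOc1ccc2c(c1)OCCC2=O`, has not yet been measured. It differs from compound 3 in one place: 2-(methyl(propargyl)amino)ethyl in place of methyl(propargyl)amino on a saturated chain carbon, six bonds along the chain from an oxygen on an aromatic ring. Going by the values given here, this is the same kind of change as the one from compound 1 to compound 2, though here it sits six bonds along the chain from an oxygen on an aromatic ring rather than four. The expected step is a number 5.1 percentage points lower from compound 3 to compound 4 (within the scatter), and that expectation rests on the measured step of a number 5.9 percentage points lower from compound 1 to compound 2 (within the scatter) having stayed within the scatter. For compound 4 in this assay the estimated value is therefore 29%, with a likely range from 16% to 42%.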

Compound 4, a percentage reported as inhibition, at one concentration (the size of the read-out at that concentration, not a potency): 28.7%
For compound 4 the middle estimate is 0.3 percentage points above the measured one, within the range that was stated.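

Putting 2-(methyl(propargyl)amino)ethyl in place of methyl(propargyl)amino on the core of compound 3 gave a number 5.4 percentage points lower from compound 3 to compound 4 (within the scatter) in this assay, so these two numbers cannot be told apart with confidence. Set beside the earlier step on the core of compound 1, the same change reads alike on both cores: the same change on two cores in this assay, a number 5.9 percentage points lower (within the scatter) from compound 1 to compound 2 and a number 5.4 percentage points lower (within the scatter) from compound 3 to compound 4, 0.5 percentage points apart, within the scatter of two such steps This agreement does not show that the change has a real effect that carries from one core to the other: neither step rises above the scatter, so the match means only that no difference can be seen on either core, and two cores say nothing about how the change would read on a third.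

The compounds shown leave open whether a longer chain, or a different amine such as dimethylamino in place of methyl(propargyl)amino, would give a number that stands clear of the others in this series. They also leave open how these compounds would compare as a measure of potency, since each number here is a read-out at one concentration and not a full dose-response curve.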